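Straightening the ester chain: compound 3 to compound 4

The source may report more compounds than this note shows. Statements on the series, on what has been measured and on what is new or still open speak of the compounds shown alone.

In an ADME assay on Vero cells (Chlorocebus sabaeus) for cytotoxicity, read by MTT assay (on this read-out lower numbers stand for stronger inhibition and higher numbers for weaker inhibition), three branched esters on the shared core spread widely: compound 1 `CCC(CC)C(=O)OCC(C)(C)CC1=C(O)C(=O)c2ccccc2C1=O` gives 104000 nM, compound 2 `CCCC(C)C(=O)OCC(C)(C)CC1=C(O)C(=O)c2ccccc2C1=O` gives 120 nM and compound 3 `CCC(C)CC(=O)OCC(C)(C)CC1=C(O)C(=O)c2ccccc2C1=O` gives 2300 nM. Compound 3 therefore holds the second highest of the three numbers. Compound 4 `CCCCCC(=O)OCC(C)(C)CC1=C(O)C(=O)c2ccccc2C1=O` differs from it only in how the same atoms are joined: butyl in place of sec-butyl on a saturated chain carbon bound to a carbonyl carbon. This places butyl in place of sec-butyl on a saturated chain carbon bound to a carbonyl carbon, which reads in full as 2-methylbutyl to pentyl.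

Among the measured compounds shown here, the steps that bear on this are the chain changes on a carbonyl carbon: an 870-fold lower number from compound 1 to compound 2 (2.94 log units; beyond the scatter), a 45-fold lower number from compound 1 to compound 3 (1.66 log units; beyond the scatter) and a 19-fold higher number from compound 2 to compound 3 (1.28 log units; beyond the scatter). All three are large and beyond the scatter, so a large move is possible. None of them leads to an unbranched chain, however, and the data give no direction. No step beyond the scatter is therefore expected as the central case, and the range stays wide on both sides. The expected step is a 1.2-fold lower number from compound 3 to compound 4 (0.06 log units; within the scatter). The estimate for compound 4 is 2000 nM, with an expected range of 200 nM to 20000 nM.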

Compound 4, half-maximal inhibitory concentration: 169000 nM
For compound 4 the middle estimate is 85-fold (1.93 log units) below the measured one, outside the stated range (above it).
By their numbers in this assay, from the lowest: compound 2; then compound 3; then compounds 1 and 4 (each within the scatter of the next).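

In this assay, the position does not tolerate this rearrangement of the same atoms: butyl in place of sec-butyl on a saturated chain carbon bound to a carbonyl carbon gives a 73-fold higher number from compound 3 to compound 4 (1.87 log units; beyond the scatter), and the unbranched ester also stands far from the 1-methylbutyl ester, with a 1400-fold higher number from compound 2 to compound 4 (3.15 log units; beyond the scatter). Branching alone does not set the number, as compound 1 is also branched, yet a 1.6-fold higher number from compound 1 to compound 4 (0.21 log units; within the scatter) leaves compound 4 within the scatter of it. Among these four esters, the lower numbers therefore belong only to the 1-methylbutyl and 2-methylbutyl chains, with compound 1 going against any rule based on branching as such. No measurement shown gives a cause for these steps.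

Still open, as far as these compounds go, is whether a longer chain, such as hexyl, follows the same pattern as pentyl. From the compounds shown here alone, the effect of an amine or a carboxylic acid on the ester chain also remains open.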